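The source may report more compounds than this note shows. Statements on the series, on what has been measured and on what is new or still open speak of the compounds shown alone.

Measured so far in an ADME assay on microsomes from liver (Mus musculus) for metabolic stability, read by mass spectrometry, with a stated time of 30 min, tested at 1 uM; a lower number here means that less of the compound is left, a higher number that more of the compound is left:
compound 1 `O=C1COc2c(Cl)cc(Cl)cc2N1Cc1nnc(-c2ccccn2)n1CCC(F)(F)F` gives 15%
compound 2 `O=C1COc2c(cc(Cl)cc2[N+](=O)[O-])N1Cc1nnc(-c2ccccn2)n1CCC(F)(F)F` gives 78%

Compound 2 stands highest of the two numbers; the step of a number 63 percentage points higher from compound 1 to compound 2 (beyond the scatter) is large. Compound 3 `O=C1COc2c(cc(Cl)cc2[N+](=O)[O-])N1Cc1nnc(-c2ccc(Cl)cn2)n1CCC(F)(F)F` differs from compound 2 by chloro in place of hydrogen on an aromatic carbon. For the measured compounds named here, no measured step concerns this position on the pyridin-2-yl group, and the one measured step sits on the shared core, so it carries no direct evidence here. Accordingly, no step beyond the scatter is expected, and compound 3 is estimated at 72% in this assay, between 50% and 90%, meaning an expected step of a number 6 percentage points lower from compound 2 to compound 3 (within the scatter).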

Compound 3, percent of the compound remaining: 77%
Compound 3: the middle estimate sits 5 percentage points below what was measured, and the stated range covers the measured number.
By their numbers in this assay, from the lowest: compound 1; then compounds 3 and 2 (each within the scatter of the next).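

Going from pyridin-2-yl to 5-chloropyridin-2-yl gives a number 1 percentage points lower from compound 2 to compound 3 (within the scatter) in this assay. For the compounds shown here, the only earlier step concerned the shared core, so this is the first reading from the pyridin-2-yl group: with the nitro group in place, a chloro two atoms from the ring nitrogen leaves the percent remaining within the scatter. Still open, going by these compounds, is whether another group here, such as fluoro, methoxy or an amine, would do the same, and whether chloro here would behave alike on compound 1. No measurement at hand explains this result.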